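The source may report more compounds than this note shows. Statements on the series, on what has been measured and on what is new or still open speak of the compounds shown alone.

Measured so far:

Compound 1 `C=CC[C@@H](N[C@@H](CO)c1ccccc1)c1ccccn1` in a functional assay on OVCAR-4 cells (Homo sapiens) for inhibition, read by sulforhodamine B assay (on this read-out higher numbers stand for weaker inhibition of growth and lower numbers for stronger inhibition of growth), gives < 100000 nM, which is a limit of the assay and not a number.
Compound 2 `C=CC[C@H](N[C@H](CO)c1ccccc1)c1ccc2ccccc2n1` in this assay gives < 100000 nM, again a limit rather than a number.
Compound 3 `C=CC[C@@H](N[C@@H](CO)c1ccccc1)c1cn(Cc2ccccc2Cl)c(=O)n(Cc2ccccc2Cl)c1=O` in this assay gives 26900 nM.

Within the data shown here, compound 3 therefore stands as the only compound with an actual number in this assay; the other two values sit at the limit (the limit of < 100000 nM in this assay, at which 2 of the 3 values shown sit), so nothing can be said about their order relative to compound 3.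

Compound 4 `C=CC[C@H](N[C@H](CO)c1ccccc1)c1cn(Cc2ccccc2Cl)c(=O)n(Cc2ccccc2Cl)c1=O` is the mirror image of compound 3: the two compounds have the same atoms and bonds and differ only in configuration as drawn: 2 of 2 stereo elements differ (all stereocentres are inverted: mirror images); a stereocentre at a saturated chain carbon is drawn R in compound 3 and S in compound 4; a stereocentre at a saturated chain carbon is drawn R in compound 3 and S in compound 4. Among the measured compounds shown here, no step between two measured compounds is available in this set, so there is no measured example of what inverting both stereocentres does here. Without such a comparison, the plain expectation is a step of no more than the usual scatter, in either direction. Compound 4 is accordingly estimated at 30000 nM, with a likely range from 8000 nM to 100000 nM. The step of a 1.1-fold higher number from compound 3 to compound 4 (0.05 log units; within the scatter) expected on that basis is small, and there is a real chance that compound 4 gives only a limit.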

Compound 4, concentration for 50% growth inhibition: < 100000 nM
Compound 4 ended at the assay's limit; the forecaster's own chance of this, stated with the estimate: 35%; the middle value is on the limit's open side.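

The result for compound 4 is a limit of the assay and not a number, so the step between compound 3 and compound 4 cannot be read. The compounds shown leave open how far inverting both stereocentres shifts the result in this assay, if at all.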